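Dimethoxyphenyl Replaces Methylphenyl on the Ring Nitrogen

The source may hold more compounds than are shown below. What is called first, only, known or untested is meant among the compounds shown, and "the series" means these compounds.

Measured compounds:
compound 1, `COc1ccc(C)cc1N1C(=O)CSC1c1cccc(C(=O)NCCCCc2ccccc2)c1`: 30%
compound 2, `Cc1cccc(N2C(=O)CSC2c2cccc(C(=O)NCCCCc3ccccc3)c2)c1`: 39%

In a functional assay on U2OS cells (Homo sapiens) for inhibition, read by CCK-8 assay, with a stated time of 72 h, tested at 1 uM (on this read-out higher numbers stand for more inhibition at the one concentration tested (going by the name of the read-out) and lower numbers for less inhibition), compound 1 gives 30%, and compound 2 gives 39%. Within the data shown here, the one step between them, a number 9 percentage points higher from compound 1 to compound 2 (within the scatter), comes with hydrogen in place of methoxy on an aromatic carbon. Compound 2 thus stands alongside compound 1, the two separated only by a gap within the scatter, so neither can be set above the other.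

Compound 3, `COc1cccc(OC)c1N1C(=O)CSC1c1cccc(C(=O)NCCCCc2ccccc2)c1`, differs from compound 2 by 2,6-dimethoxyphenyl in place of 3-methylphenyl on an amide-type nitrogen in a ring. Among the measured compounds shown here, the only measured step that bears on this change is a number 9 percentage points higher from compound 1 to compound 2 (within the scatter), in which a single methoxy left the ring on the ring nitrogen and the number moved within the scatter. For the measured compounds named here, no measured step introduces two methoxy groups or removes the methyl, so the present change is larger than anything yet tested. Going by the values given here, with the one relevant step so small, no shift beyond the scatter is expected, and the estimated step is a number 7 percentage points lower from compound 2 to compound 3 (within the scatter). Compound 3 is therefore expected to give 32%, within a range from 14% to 50%.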

Compound 3, a percentage reported as inhibition, at one concentration (the size of the read-out at that concentration, not a potency): 41%
Beside the measured number, compound 3's estimate is 9 percentage points below it; low and high end bracket the measured number.
By their numbers in this assay, from the lowest: compounds 1, 2 and 3 (each within the scatter of the next, the first and the last beyond it).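

In this assay, the step of a number 2 percentage points higher from compound 2 to compound 3 (within the scatter) shows that 2,6-dimethoxyphenyl, with its two hydrogen-bond acceptors and larger count of heavy atoms, can stand on this amide-type nitrogen in a ring in place of 3-methylphenyl without the two compounds being separable. Among these compounds, the step of a number 11 percentage points higher from compound 1 to compound 3 (beyond the scatter), with 2,6-dimethoxyphenyl in place of 2-methoxy-5-methylphenyl, is the first at this position to lie beyond the scatter, so the choice of substituted phenyl group here can move the number modestly, although compound 2 cannot be separated from either of the other two. The data offer no explanation for either step.

On these data alone, whether an amine or a carboxylic acid on this phenyl ring, or a cyclohexyl group in place of the ring, would carry the number further remains open. As far as these compounds go, all three compounds also share the phenylbutyl chain on the other amide and were read at one concentration, so the effect of a shorter or longer chain there and the potency of any of them stay unknown.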